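Working notes: aryl swap from compound 3 to compound 4

The source may hold more compounds than are shown below. What is called first, only, known or untested is meant among the compounds shown, and "the series" means these compounds.

Of the compounds shown here, three have been read in an ADME assay on HEK-293T cells (Homo sapiens) for cytotoxicity, read by MTT assay, with a stated time of 48 h; on this read-out lower numbers stand for higher toxicity in this test and higher numbers for lower toxicity in this test. Compound 1 `O=C(Nc1cnn(-c2ccccc2)c1)c1cccc(NS(=O)(=O)c2ccccc2)c1` gives 110000 nM. Compound 2 `Cc1ccc(-n2cc(NC(=O)c3cccc(NS(=O)(=O)c4ccccc4)c3)cn2)cc1` gives 93800 nM, reached by a 1.2-fold lower number from compound 1 to compound 2 (0.07 log units; within the scatter). Compound 3 `Cc1ccc(-n2cc(NC(=O)c3cccc(NS(=O)(=O)c4ccc(Cl)cc4)c3)cn2)cc1` gives 110000 nM, reached by a 1.2-fold higher number from compound 2 to compound 3 (0.07 log units; within the scatter). At the digits shown compound 3 stands level with compound 1, and all three numbers lie within the scatter of one another, so none of the three can be set apart in this assay.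

Compound 4 `COc1cccc(-n2cc(NC(=O)c3cccc(NS(=O)(=O)c4ccc(Cl)cc4)c3)cn2)c1` has not yet been measured in this assay. It differs from compound 3 by 3-methoxyphenyl in place of 4-methylphenyl on an aromatic nitrogen. Within the data shown here, no measured step covers this exact change. The two steps in hand, a 1.2-fold lower number from compound 1 to compound 2 (0.07 log units; within the scatter) and a 1.2-fold higher number from compound 2 to compound 3 (0.07 log units; within the scatter), each alter a substituent on an aromatic carbon and each stayed within the scatter. On that basis a step of a 1.1-fold lower number from compound 3 to compound 4 (0.04 log units; within the scatter) is expected, that is, no movement beyond the scatter in either direction. Compound 4 is therefore estimated at 100000 nM, with a range from 50000 nM to 200000 nM.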

Compound 4, half-maximal cytotoxic concentration: 133000 nM
For compound 4 the middle estimate is 1.3-fold (0.12 log units) below the measured one; the range from low to high includes it.
By their numbers in this assay, from the lowest: compounds 2, 1, 3 and 4 (each within the scatter of the next).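

In this assay the exchange of 4-methylphenyl for 3-methoxyphenyl on the aromatic nitrogen gives a 1.2-fold higher number from compound 3 to compound 4 (0.08 log units; within the scatter) and so makes no readable difference. Unlike the earlier steps, which each altered a substituent on an aromatic carbon, this one replaces the whole aryl group at this position and brings in a hydrogen-bond acceptor where the leaving group has none, and the read-out still stays within the scatter. No data are at hand that would explain this result.

As far as these compounds go, with each compound within the scatter of the next, it remains open whether any change at this position can move the read-out at all. An amine or a carboxylic acid on this aryl group, or a longer alkyl chain in its place, would test that.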